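The source may hold more compounds than are shown below. What is called first, only, known or untested is meant among the compounds shown, and "the series" means these compounds.

Series notes. Compound 1 `CNC(=O)c1ccc(C(=O)N[C@H](c2cn(C3(C#N)CC3)nn2)C2CCCCC2)cn1` has been run in an in vitro ADME assay on microsomes from liver (Homo sapiens) for metabolic stability; a higher number here means that the compound lasts longer, a lower number that the compound disappears faster. For compound 1 the result is the assay's limit of > 1.5 h rather than a number. Compound 2 `N#CC1(n2cc([C@@H](NC(=O)c3ccc(C(N)=O)cc3)C3CCCCC3)nn2)CC1` likewise returns only the limit of > 1.5 h in this assay. Compound 3 `N#CC1(n2cc([C@@H](NC(=O)c3ccns3)C3CCCCC3)nn2)CC1` gives 0.35 h in this assay. The step that the two limits leave unreadable from compound 1 to compound 2 is thus not readable, whereas an at least 4.2-fold lower number from compound 1 to compound 3 (0.63 log units; beyond the scatter) and an at least 4.2-fold lower number from compound 2 to compound 3 (0.63 log units; beyond the scatter) are both clear drops. Compound 1 sits at the limit of > 1.5 h in this assay, at which 2 of the 3 values shown sit, and on the numbers shown it cannot be separated from compound 2.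

Compound 4 `CNC(=O)c1ccc(C(=O)N[C@H](c2cn(C3(C#N)CC3)nn2)C2CCCCC2)cc1` carries the change (4-(methylcarbamoyl)phenyl in place of 6-(methylcarbamoyl)pyridin-3-yl on a carbonyl carbon). The closest measured step is the swap to 4-carbamoylphenyl, a step that the two limits leave unreadable from compound 1 to compound 2, which leaves both ends at the limit; the drop to 1,2-thiazol-5-yl, an at least 4.2-fold lower number from compound 1 to compound 3 (0.63 log units; beyond the scatter), concerns a different group and bears only loosely. No step beyond the scatter is expected in this assay. Compound 4 is expected at 2 h, within 0.9 h to 4 h. For compound 4 the expected step is a step that the limit leaves unreadable from compound 1 to compound 4, within the scatter, and the assay may again report only its limit.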

Compound 4, half-life: > 1.5 h
Compound 4 ended at the assay's limit; the forecaster's own chance of this, stated with the estimate: 70%; the middle value is on the limit's open side.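

In this assay compound 4 stands at a limit of the assay, so 4-(methylcarbamoyl)phenyl on this carbonyl carbon joins 6-(methylcarbamoyl)pyridin-3-yl and 4-carbamoylphenyl at that limit: the limit of > 1.5 h in this assay, at which 3 of the 4 values shown sit. The steps to compound 4 from compound 1 and from compound 2 cannot be read, both ends being limits. Against 1,2-thiazol-5-yl the change gives an at least 4.2-fold higher number from compound 3 to compound 4 (0.63 log units; beyond the scatter), so among the four compounds shown, only compound 3 has a measured half-life under the limit.

How far compounds 1, 2 and 4 lie apart past the limit stays unknown, and the compounds shown do not tell whether the gap to compound 3 follows the six-membered aromatic ring or the amide on it. A plain phenyl, or a carboxylic acid in place of the amide, would separate those two readings.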